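Methoxybenzyl groups on a bombesin receptor subtype-3 agonist core

The source may report more compounds than this note shows. Statements on the series, on what has been measured and on what is new or still open speak of the compounds shown alone.

Measured compounds:
- compound 1 `COc1ccc(Cc2cnc(CCc3ccc(-c4ccccc4C(=O)O)cc3)[nH]2)cc1`, 513 nM
- compound 2 `O=C(O)c1ccccc1-c1ccc(CCc2ncc(-c3ccccc3)[nH]2)cc1`, 872 nM

Both compounds were tested in an in vitro functional assay on cells for agonist activity at Bombesin receptor subtype-3 (Mus musculus), read by luminescence and calcium flux; on this read-out lower numbers stand for an effect already at smaller amounts and higher numbers for an effect only at larger amounts of compound. On the two numbers at hand, compound 2 has the higher one, but its nearest neighbour compound 1 sits within the scatter of it, so the two cannot be ranked with confidence.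

The step from compound 2 to compound 3 `COc1ccccc1Cc1cnc(CCc2ccc(-c3ccccc3C(=O)O)cc2)[nH]1` is 2-methoxybenzyl in place of phenyl on an aromatic carbon. For the measured compounds named here, one measured step bears on this change: a 1.7-fold higher number from compound 1 to compound 2 (0.23 log units; within the scatter). That step exchanges a methoxybenzyl group for phenyl at the same ring carbon and stays within the scatter; the present step reverses it with the methoxy group placed differently on the benzyl ring. From this, no movement beyond the scatter is expected, with the number most likely falling near that of compound 1 rather than rising further. Compound 3 is therefore estimated to give 550 nM in this assay, with a range from 200 nM to 1500 nM. This estimate corresponds to an expected step of a 1.6-fold lower number from compound 2 to compound 3 (0.20 log units; within the scatter).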

Compound 3, half-maximal effective concentration: 163 nM
For compound 3 the middle estimate is 3.4-fold (0.53 log units) above the measured one; measured number outside the range, below it.
By their numbers in this assay, from the lowest: compound 3; then compounds 1 and 2 (each within the scatter of the next).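

In this assay, the ring carbon that carries the phenyl group of compound 2 proves responsive after all: 2-methoxybenzyl in that place gives a 5.3-fold lower number from compound 2 to compound 3 (0.73 log units; beyond the scatter), whereas the earlier exchange of 4-methoxybenzyl for phenyl gave only a 1.7-fold higher number from compound 1 to compound 2 (0.23 log units; within the scatter). The comparison of the two methoxybenzyl groups adds what the earlier pair could not show, namely that the place of the methoxy group on the benzyl ring counts at this position, with a 3.1-fold lower number from compound 1 to compound 3 (0.50 log units; beyond the scatter) on going from the 4-methoxybenzyl to the 2-methoxybenzyl group. Nothing at hand accounts for this difference between the two groups.

The step from phenyl to 2-methoxybenzyl changes both the chain between the rings and the methoxy group at once, so the shares of the two changes in the gain cannot be separated, and a plain benzyl group or a 2-methoxyphenyl group at the same carbon would be needed to tell them apart. From the compounds shown here alone, how a 3-methoxybenzyl group, or a 2-ethoxybenzyl group with a longer chain on the oxygen, would compare with the 2-methoxybenzyl group of compound 3 also remains open.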